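Moving the Chlorine on the Benzyl Thioether

The source may report more compounds than this note shows. Statements on the series, on what has been measured and on what is new or still open speak of the compounds shown alone.

Measured so far in a functional assay on the whole organism (artery, strain albino) with Rattus norvegicus as the target, with a stated time of 360 min, at a dose of 10 mg/kg by the oral route; a lower number here means less inhibition, a higher number more inhibition at the dose given (going by the name of the read-out):
compound 1, `CC1=C(C(=O)Nc2ccc(Br)cc2)C(c2ccc(Cl)cc2Cl)N=C(SCc2cccc(Cl)c2)N1`: 20.6%
compound 2, `CC1=C(C(=O)Nc2ccc(Br)cc2)C(c2ccc(Cl)cc2Cl)N=C(SCc2ccc(Cl)cc2)N1`: 39.7%
compound 3, `CC1=C(C(=O)Nc2ccc([N+](=O)[O-])cc2)C(c2ccc(Br)cc2)N=C(SCc2cccc(Cl)c2)N1`: 7.2%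

Compound 3 stands lowest of the three, below compound 1 and further below compound 2, both gaps beyond the scatter. Compound 2 differs from compound 1 by 4-chlorophenyl in place of 3-chlorophenyl on a saturated chain carbon bound to a sulfur, and that change made a step of a number 19.1 percentage points higher from compound 1 to compound 2 (beyond the scatter) in this assay. How the core of compound 3 differs from the core of compound 1 is not broken down here.

Compound 4, `CC1=C(C(=O)Nc2ccc([N+](=O)[O-])cc2)C(c2ccc(Br)cc2)N=C(SCc2ccc(Cl)cc2)N1`, has not yet been measured. It differs from compound 3 by 4-chlorophenyl in place of 3-chlorophenyl on a saturated chain carbon bound to a sulfur, the same change as from compound 1 to compound 2, at the same place. Resting on the single step of a number 19.1 percentage points higher from compound 1 to compound 2 (beyond the scatter), compound 4 is expected to show a step of a number 16.8 percentage points higher from compound 3 to compound 4 (beyond the scatter). With one earlier example only, the range is wide. Compound 4 is estimated at 24% in this assay, between 8% and 42%.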

Compound 4, a percentage reported as inhibition, in the whole organism at one dose (the size of the read-out at that dose, not a potency): 39.2%
Beside the measured number, compound 4's estimate is 15.2 percentage points below it, within the range that was stated.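

In this assay, 4-chlorobenzyl in place of 3-chlorobenzyl on the sulfur gave a number 32 percentage points higher from compound 3 to compound 4 (beyond the scatter). The change therefore pointed the same way on both cores, and the two steps cannot be told apart in size: the same change on two cores in this assay, a number 19.1 percentage points higher (beyond the scatter) from compound 1 to compound 2 and a number 32 percentage points higher (beyond the scatter) from compound 3 to compound 4, 12.9 percentage points apart, within the scatter of two such steps. This supports carrying the change between these two cores only; it does not show that the step would hold on any other core, or which parts of these cores matter, and a read-out at one dose is no measure of potency.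

The benzyl groups shown carry only chlorine, so a plain benzyl, a 4-fluorobenzyl or a 4-methoxybenzyl group remains open. So does a longer chain between the sulfur and the ring.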